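Extending the para substituent on the pendant phenyl ring

The compounds below may be only part of what the source reports. "The series", "measured", "known", "first", "only" and "open" are said of these compounds alone.

The three measured compounds share one core and differ only at the para position of the pendant phenyl ring. Compound 1 `Clc1ccc(CO/N=C/c2c(-c3ccccc3)nc3sccn23)cc1Cl` carries hydrogen there and gives 580 nM in an assay on HepG2 cells for agonist activity at nuclear receptor subfamily 1 group I member 3 (Homo sapiens), read by a luciferase reporter, with a stated time of 23 h; on this read-out lower numbers stand for an effect already at smaller amounts and higher numbers for an effect only at larger amounts of compound. Compound 2 `COc1ccc(-c2nc3sccn3c2/C=N/OCc2ccc(Cl)c(Cl)c2)cc1` carries methoxy and gives 490 nM. Compound 3 `Fc1ccc(-c2nc3sccn3c2/C=N/OCc2ccc(Cl)c(Cl)c2)cc1` carries fluoro and gives 670 nM. The steps of a 1.2-fold lower number from compound 1 to compound 2 (0.07 log units; within the scatter), a 1.2-fold higher number from compound 1 to compound 3 (0.06 log units; within the scatter) and a 1.4-fold higher number from compound 2 to compound 3 (0.14 log units; within the scatter) all lie within the scatter, so the three numbers cannot be told apart; compound 3 sits among them rather than apart from them.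

Compound 4 `Clc1ccc(CO/N=C/c2c(-c3ccc(-c4ccccc4)cc3)nc3sccn23)cc1Cl` is the next member, differing from compound 3 by phenyl in place of fluoro on an aromatic carbon. The measured steps at this position, all small, bear on it only indirectly, since none of them introduces a ring; they show that the para position has so far tolerated hydrogen, methoxy and fluoro without a step beyond the scatter. On that basis no step beyond the scatter is expected, with wide uncertainty for the larger group. Compound 4 is therefore estimated at 650 nM, in the range 200 nM to 2500 nM, a step of a 1.0-fold lower number from compound 3 to compound 4 (0.01 log units; within the scatter).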

Compound 4, half-maximal effective concentration: "not active" (no number reported)
No number was reported for compound 4, and the estimate cannot be compared.
By their numbers in this assay, from the lowest: compounds 2, 1 and 3 (each within the scatter of the next).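

Within the data shown here, compound 4 is reported as not active in this assay, with no number, so no step from compound 3 to compound 4 can be read. Nothing shown accounts for this result. The compounds shown leave open whether any other ring-bearing group at this place would give a number.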